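A few compounds are considered here, and "the series" means these few. Any claim that something is new, unique, unknown or untested is made for them only; others in the source may bear on it.

Compound 1 `CC(C)C(NC(=O)NO)C(=O)NC1CCCC1` and compound 3 `CC(C)C(NC(=O)n1nnc2ccccc21)C(=O)NC1CCCCC1` share the same kind of amide-type scaffold, though the difference between their two cores is not broken down here. In a functional assay on MIA PaCa-2 cells (Homo sapiens) for inhibition (a higher number here means a weaker inhibitor, a lower number a stronger inhibitor), compound 1 gives only a limit of the assay, > 100000 nM. Compound 3 likewise gives only a limit of this assay, > 100000 nM. Compound 2 `CCC(C)C(NC(=O)n1nnc2ccccc21)C(=O)NC1CCCCC1` carries the change methyl in place of hydrogen on a saturated chain carbon, three bonds along the chain from an amide-type nitrogen and a carbonyl carbon on the core of compound 3, and in this assay compound 2 gives 40200 nM. That change produced an at least 2.4-fold lower number from compound 3 to compound 2 (0.39 log units; beyond the scatter), and the size of that step can only be stated as a bound, because of the limit of > 100000 nM in this assay, at which 2 of the 3 values shown sit.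

Compound 4 `CCC(C)C(NC(=O)NO)C(=O)NC1CCCC1` carries the same change methyl in place of hydrogen on a saturated chain carbon, three bonds along the chain from an amide-type nitrogen and a carbonyl carbon on the core of compound 1. The step from compound 1 to compound 4 in this assay is expected to be roughly the size seen for compound 3 in an at least 2.4-fold lower number from compound 3 to compound 2 (0.39 log units; beyond the scatter), namely an at least 1.2-fold lower number from compound 1 to compound 4 (0.09 log units; that floor lies within the scatter), since the value of compound 1, > 100000 nM, is itself only a limit. Compound 4 is therefore estimated at about 80000 nM in this assay, between 30000 nM and 300000 nM.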

Compound 4, half-maximal inhibitory concentration: > 100000 nM
Compound 4 was reported as a limit (the forecaster's own chance of this, stated with the estimate: 60%); at least 1.2-fold (0.09 log units) between middle value and limit.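

In this assay compound 4 gives only a limit of the assay, > 100000 nM. Compound 1 also gives only a limit, so no step can be read between compound 1 and compound 4: the limit of > 100000 nM in this assay, at which 3 of the 4 values shown sit.

The compounds shown leave open whether methyl in place of hydrogen lowers the number at all on the core of compound 1, as it does on the core of compound 3.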